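From Chloro to Amino in a P388 Cell Assay

The source may hold more compounds than are shown below. What is called first, only, known or untested is meant among the compounds shown, and "the series" means these compounds.

Three related compounds have been tested in a functional assay on P388 cells (Mus musculus) for inhibition; on this read-out lower numbers stand for an effect already at smaller amounts and higher numbers for an effect only at larger amounts of compound. Compound 1 `Nc1nc(Cl)c2ncn(C3C=CC(CO)C3)c2n1` gives 75 ug/mL. Compound 2 `Nc1nc(Cl)c2nnn(C3CCC(CO)C3)c2n1` gives 18 ug/mL, the lower of the two actual numbers, and its gap to compound 1 lies beyond the usual scatter. Compound 3 `Nc1nc(N)c2nnn(C3C=CC(CO)C3)c2n1` gives > 100 ug/mL, which is a limit of the assay and not a number. Among the compounds with values here, compound 2 therefore stands as the best-placed of the three on the numbers so far.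

The next compound to be tested is compound 4 `Nc1nc(N)c2nnn(C3CCC(CO)C3)c2n1`. It has amino in place of chloro on an aromatic carbon, with the rest of compound 2 unchanged (amino in place of chloro on an aromatic carbon). Within the data shown here, no measured pair isolates this exchange. Compound 3 does carry the amino group, but it also differs from compound 4 elsewhere in its structure, so it offers only indirect guidance. Even so, the account leans towards a higher number in this assay, with a step expected to lie beyond the scatter. The expected step is a 3.9-fold higher number from compound 2 to compound 4 (0.59 log units; beyond the scatter). The estimated value for compound 4 is 70 ug/mL, with an expected range from 25 ug/mL to 200 ug/mL.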

Compound 4, concentration for half-maximal effect: > 100 ug/mL
Compound 4 gave a limit, no number; the forecaster's own chance of this, stated with the estimate: 40%; middle value at least 1.4-fold (0.15 log units) away from the limit.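

Within the data shown here, for the first time, a single pair isolates amino in place of chloro on an aromatic carbon, next to the ring nitrogen, with the rest of the structure unchanged. In this assay this exchange gives an at least 5.5-fold higher number from compound 2 to compound 4 (0.74 log units; beyond the scatter), so at this position the chloro group is the one tied to the measurable number, and the earlier indirect hint from the amino group in compound 3 now has a direct counterpart. Even so, the step fixes a direction and a minimum size, not a full size: the limit of > 100 ug/mL in this assay, at which 2 of the 4 values shown sit.

The step between compound 3 and compound 4 cannot be read, since each of the two stands at a limit and not at a number. Going by these compounds, whether another group on this aromatic carbon, such as a methoxy group, a thiol or a methylamino group, would stay close to compound 2 or would also move to the limit remains open, as does how far the amino compounds truly lie from compound 2.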